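Tetrazolyl for thiadiazolyl: a single-point aromatic swap

The source may report more compounds than this note shows. Statements on the series, on what has been measured and on what is new or still open speak of the compounds shown alone.

Going by the values given here, compound 2 `CCC(C)(C)Cc1c[nH]c(CCc2ccc(-c3csnn3)cc2)n1` carries a 1,2,3-thiadiazol-4-yl group on the six-membered aromatic ring of carbon only, and in an in vitro assay on CHO cells for displacement of a labelled ligand from Bombesin receptor subtype-3 (Homo sapiens), read by scintillation counting, with a stated time of 2 h (a lower number here means a stronger inhibitor, a higher number a weaker inhibitor), compound 2 gives 45 nM, the lowest of the three numbers measured so far. Compound 3 `CCC(C)(C)Cc1c[nH]c(CCc2ccc(-c3cnccn3)cc2)n1`, with pyrazin-2-yl in that place, gives 51 nM in this assay; the step of a 1.1-fold higher number from compound 2 to compound 3 (0.05 log units; within the scatter) lies within the scatter, so the two stand level. Compound 1 `c1ccc(-c2ccc(CCc3nc(CC4CCCC4)c[nH]3)cc2)nc1` differs from compound 2 at both ends of the shared core. In this assay, among the compounds with values here, compound 1 gives 177 nM, the furthest from compound 2 and beyond the scatter; no single-place step links it to compound 2.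

Compound 4 `CCC(C)(C)Cc1c[nH]c(CCc2ccc(-n3ncnn3)cc2)n1` differs from compound 2 in one place: 2H-tetrazol-2-yl in place of 1,2,3-thiadiazol-4-yl on an aromatic carbon. Within the data shown here, the one measured step that bears on this change is a 1.1-fold higher number from compound 2 to compound 3 (0.05 log units; within the scatter), an exchange of one aromatic heterocycle for another on the same aromatic carbon, which left the number within the scatter. A 2H-tetrazol-2-yl in place of 1,2,3-thiadiazol-4-yl is the same kind of exchange, so a step of a 1.3-fold higher number from compound 2 to compound 4 (0.12 log units; within the scatter) is expected, not beyond the scatter in either direction. For compound 4 in this assay the estimate is 60 nM, with a range of 25 nM to 150 nM.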

Compound 4, half-maximal inhibitory concentration: 205 nM
Compound 4: middle estimate off by 3.4-fold (0.53 log units), on the low side; the measured number lies above the stated range.
By their numbers in this assay, from the lowest: compounds 2 and 3 (each within the scatter of the next); then compounds 1 and 4 (each within the scatter of the next).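

Working notes on this position: the aromatic carbon para to a large group does not treat all aromatic heterocycles alike. In this assay the exchange of 1,2,3-thiadiazol-4-yl for pyrazin-2-yl stayed within the scatter, with a 1.1-fold higher number from compound 2 to compound 3 (0.05 log units; within the scatter), but 2H-tetrazol-2-yl stands apart from both groups, with a 4.6-fold higher number from compound 2 to compound 4 (0.66 log units; beyond the scatter) and a 4.0-fold higher number from compound 3 to compound 4 (0.60 log units; beyond the scatter), so the earlier level pair does not extend to every heterocycle here. The tetrazolyl keeps the five-membered aromatic ring, the heavy-atom count and the absence of net charge of the thiadiazolyl, so this step goes with a change in ring atoms and in the link, since 2H-tetrazol-2-yl is joined through a ring nitrogen, and nothing available accounts for the step or separates those two differences.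

Open, from the compounds shown here alone, is whether the step follows the link or the ring atoms: 1H-imidazol-1-yl would keep the nitrogen link with fewer ring nitrogens, while 2H-tetrazol-5-yl would keep the tetrazole ring with a carbon link. Also open, going by these compounds, is how a non-ring group such as a carboxylic acid or an amine would fare on this same aromatic carbon.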